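This account rests on a few compounds, and the source may have more. Where it says the series, first, only, none or still open, it means among the compounds named here.

Going by the values given here, in a functional assay on BGC-823 cells (Homo sapiens) for cytotoxicity, read by MTT assay, with a stated time of 48 h (on this read-out higher numbers stand for weaker inhibition and lower numbers for stronger inhibition), compound 2 `COc1cc(/C=N/NC(=O)CSc2nnc(-c3ccncc3)o2)ccc1O` gives 4320 nM and holds the lower of the two numbers so far, while compound 1 `COc1ccc(/C=N/NC(=O)CSc2nnc(-c3ccncc3)o2)cc1` gives 19800 nM on the same read-out. The change to compound 3 `O=C(CSc1nnc(-c2ccncc2)o1)N/N=C/C=C/c1ccccc1` is 2-phenylethenyl in place of 4-hydroxy-3-methoxyphenyl on a carbon with a double bond to nitrogen and it puts 2-phenylethenyl in place of 4-hydroxy-3-methoxyphenyl. Among the compounds with values here, the one measured step that bears on it is a 4.6-fold lower number from compound 1 to compound 2 (0.66 log units; beyond the scatter) and it is modest, with 4-hydroxy-3-methoxyphenyl on the lower side. Compound 3 lacks that group as well, so the expected move is a 2.8-fold higher number from compound 2 to compound 3 (0.44 log units; beyond the scatter) toward weaker inhibition, of similar size. Compound 3 is expected to read 12000 nM with an estimated range of 4000 nM to 35000 nM in this assay once measured.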

Compound 3, half-maximal inhibitory concentration: 10600 nM
Compound 3: middle estimate off by 1.1-fold (0.05 log units), on the high side; the range from low to high includes it.
By their numbers in this assay, from the lowest: compound 2; then compounds 3 and 1 (each within the scatter of the next).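

In this assay, 2-phenylethenyl does not match 4-hydroxy-3-methoxyphenyl at this position, with a 2.5-fold higher number from compound 2 to compound 3 (0.39 log units; beyond the scatter). Against the 4-methoxyphenyl group the same swap gives a 1.9-fold lower number from compound 1 to compound 3 (0.27 log units; within the scatter), so only compound 2 stands apart from the other two, and a phenyl ring carrying no oxygen, set on a carbon-carbon double bond, reads like the methoxy one. Nothing measured here offers a reason for this. The compounds shown leave open whether a plain 4-hydroxyphenyl group would read like compound 2. On these data alone, how an amine or a carboxylic acid on that phenyl ring would read also stays open.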